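Taking the bromo group off compound 2

The source may hold more compounds than are shown below. What is called first, only, known or untested is meant among the compounds shown, and "the series" means these compounds.

In a functional assay on MGC-803 cells (Homo sapiens) for inhibition, read by CCK-8 assay, with a stated time of 48 h (a higher number here means a weaker inhibitor, a lower number a stronger inhibitor), compound 2 (`COc1ccc(CN(C(=O)CSC(=S)N2CCN(C(=O)OC(C)(C)C)CC2)c2ccc(Br)cc2)cc1`) gives > 20000 nM as a limit, not a number. Compound 1 (`COc1ccc(CN(C(=O)CSC(=S)N2CCN(C(=O)OC(C)(C)C)CC2)c2ccc(Cl)cc2)cc1`) gives > 20000 nM as a limit too. Compound 3 (`COc1ccc(CN(C(=O)CSC(=S)N2CCN(C(=O)OC(C)(C)C)CC2)c2ccccc2)cc1`) carries hydrogen in place of bromo on an aromatic carbon. The nearest measured change (a step that the two limits leave unreadable from compound 1 to compound 2) swaps one halogen for another and has no readable size, while the measured values stand at the limit of > 20000 nM in this assay, at which 2 of the 2 values shown sit, and offer no other guide. No step beyond the scatter is expected (a step that the limit leaves unreadable from compound 2 to compound 3), and no direction can be expected either. Compound 3 is estimated at 25000 nM (range 10000 nM to 40000 nM), and it will most likely be reported as a limit again.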

Compound 3, half-maximal inhibitory concentration: > 20000 nM
Compound 3: no number, only a limit; the forecaster's own chance of this, stated with the estimate: 85%; the middle value does not contradict the limit.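

Compound 1, compound 2 and compound 3 all give only a limit in this assay, so no step among them can be read: the limit of > 20000 nM in this assay, at which 3 of the 3 values shown sit.

These compounds leave open whether chloro, bromo or hydrogen on that aromatic carbon changes inhibition at all.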